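The source may hold more compounds than are shown below. What is called first, only, known or untested is meant among the compounds shown, and "the series" means these compounds.

Measured so far in a functional assay on HL-60 cells (Homo sapiens) for inhibition, read by MTT assay, with a stated time of 48 h, tested at 10 uM; on this read-out lower numbers stand for less inhibition of growth and higher numbers for more inhibition of growth at the one concentration tested:
- compound 1 `Cc1cc(=O)c2c(O)cc(OCc3ccc([N+](=O)[O-])cc3)c([C@H]3CCN(C)C[C@H]3O)c2o1`: 14%
- compound 2 `CN1CC[C@H](c2c(O)cc(O)c3c(=O)cc(/C=C/c4ccccc4)oc23)[C@H](O)C1`: 91%
- compound 3 `CN1CC[C@H](c2c(O)cc(O)c3c(=O)cc(/C=C/c4c(F)c(F)c(F)c(F)c4F)oc23)[C@H](O)C1`: 80%

Among these, compound 3 stands in the middle at 80%, below compound 2 at 91% and far above compound 1 at 14%. The next compound to be tested is compound 4 `CN1CC[C@H](c2c(O)cc(O)c3c(=O)cc(/C=C/c4ccccc4Cl)oc23)[C@H](O)C1`. It differs from compound 3 in a single place, on a double-bonded chain carbon bound to a double-bonded chain carbon: 2-chlorophenyl in place of 2,3,4,5,6-pentafluorophenyl on a double-bonded chain carbon bound to a double-bonded chain carbon.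

For the measured compounds named here, only one measured step bears on this change, and it concerns the same place: a number 11 percentage points lower from compound 2 to compound 3 (beyond the scatter). This step is modest, though beyond the scatter. Going by the values given here, compound 1 is linked to the others by no single-place step, so it offers no guide here. Among the compounds with values here, no compound with a 2-chlorophenyl group has been measured, so the data show only that the phenyl and the 2,3,4,5,6-pentafluorophenyl compounds both give high numbers. Compound 4 is therefore expected to stay in that high range, probably between the two, with only a small upward move in this assay. The step expected is a number 5 percentage points higher from compound 3 to compound 4 (within the scatter). For compound 4 the estimated value is 85%, with an expected range from 68% to 96%.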

Compound 4, percent growth inhibition at one concentration: 61%
Estimate against measurement, compound 4: 24 percentage points above; measured number below the stated range.
By their numbers in this assay, from the lowest: compound 1; then compound 4; then compound 3; then compound 2.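

In this assay, the group on the double-bonded chain carbon bound to a double-bonded chain carbon matters more than the earlier pair suggested. Chloro in place of hydrogen on an aromatic carbon gives a number 30 percentage points lower from compound 2 to compound 4 (beyond the scatter), a larger step than the one seen with full fluorination, a number 11 percentage points lower from compound 2 to compound 3 (beyond the scatter), even though the 2-chlorophenyl group carries one halogen atom and the 2,3,4,5,6-pentafluorophenyl group carries five. The direct exchange gives a number 19 percentage points lower from compound 3 to compound 4 (beyond the scatter), so among these compounds the number does not fall in step with the count of halogen atoms on the ring, and nothing measured here explains this order.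

The compounds shown leave open whether a 2-fluorophenyl or a 2-methylphenyl group at this place would give a number closer to that of compound 2 or to that of compound 4, which would help tell whether the lower number is specific to chlorine. They also leave open how a nitrogen-containing ring such as pyridyl would behave at this place, since all three groups compared here are six-membered aromatic rings of carbon only.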